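Core series: intrinsic clearance in human liver microsomes

The source may hold more compounds than are shown below. What is called first, only, known or untested is meant among the compounds shown, and "the series" means these compounds.

Measured compounds:
compound 1 `C[C@@H]1CC(=O)N(c2cnc(NCc3c(F)ccc4c3CCO4)n3cnnc23)C1` — < 3 mL.min-1.g-1
compound 2 `CNC(=O)c1ccc(-c2cnc(NCc3c(F)ccc4c3CCO4)c3cn[nH]c(=O)c23)c(C)n1` — 23 mL.min-1.g-1

Two compounds on the shared core carry a result in an ADME assay on microsomes from liver (Homo sapiens) for metabolic stability, read by LC-MS, using NADPH, with stated times of 5 min and 30 min, tested at 1 uM; a lower number here means slower removal, a higher number faster removal of the compound. For compound 1 the reported < 3 mL.min-1.g-1 is a limit of the assay and not a number, so compound 1 is placed only by that limit (the limit of < 3 mL.min-1.g-1 in this assay, at which 1 of the 2 values shown sits). Within the data shown here, compound 2 gives 23 mL.min-1.g-1 in this assay, the one numerical value in the set.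

Compound 3 `CN(c1cccnc1)c1cnc(NCc2c(F)ccc3c2CCO3)n2cnnc12` has not been measured in this assay. It differs from compound 1 in a single place: methyl(pyridin-3-yl)amino in place of 4-methyl-2-oxopyrrolidin-1-yl on an aromatic carbon. Among the measured compounds shown here, no pair of measured compounds differing in one place is on record, so the size of this change cannot be read from a measured step. The expected step of an at least 2.3-fold higher number from compound 1 to compound 3 (0.36 log units; beyond the scatter) is a small rise in this assay, estimated to sit close to the edge of the usual scatter rather than clearly beyond it. Compound 3 is expected to give 7 mL.min-1.g-1, with a range from 3 mL.min-1.g-1 to 20 mL.min-1.g-1, and a fair chance that only a limit is reported.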

Compound 3, intrinsic clearance in microsomes: 80 mL.min-1.g-1
Estimate against measurement, compound 3: 11-fold (1.06 log units) below, and the stated range ends below it.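

At this aromatic carbon, methyl(pyridin-3-yl)amino in place of 4-methyl-2-oxopyrrolidin-1-yl gives, in this assay, an at least 26-fold higher number from compound 1 to compound 3 (1.42 log units; beyond the scatter), a large change from one exchange with the rest of the molecule held constant. Among these compounds, this is the first measured step, and it shows that the group at this position can by itself move the read-out far beyond the scatter, which compound 1 and compound 2 could not show as they differ in more than one place. Compound 1 carries a limit of the assay and not a number, < 3 mL.min-1.g-1, so the step gives only a lower bound on the change and its full size stays unknown: the limit of < 3 mL.min-1.g-1 in this assay, at which 1 of the 3 values shown sits.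

On these data alone, it remains open which part of the entering group goes with the rise: the pyridine ring, its ring nitrogen, or the methyl on the linking nitrogen. Dimethylamino, methyl(phenyl)amino or an unsubstituted 2-oxopyrrolidin-1-yl at this carbon would divide the step into smaller parts, and whether any amine-linked aromatic ring here can stay near the limit held by compound 1 is equally unsettled.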